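Swapping Hydroxy for Phenyl on a Shared Core

The compounds below may be only part of what the source reports. "The series", "measured", "known", "first", "only" and "open" are said of these compounds alone.

Three compounds built on the same fused two-ring core were tested in an ADME assay on L1210/0 cells (Mus musculus) for cytotoxicity, with a stated time of 48 h; a lower number here means a stronger inhibitor, a higher number a weaker inhibitor. Compound 1 `Oc1ncnc2c1ncn2C[C@@H]1C[C@H](O)c2ccccc21` carries a hydroxy on that core. In this assay compound 1 gives only a limit, > 200000 nM, and not a measured number. Compound 1 therefore sits at the weak end of the numbers shown, described by the limit of > 200000 nM in this assay, at which 1 of the 3 values shown sits. Compound 2 `OC[C@H]1C[C@@H](Cn2cnc3c(-c4ccc(Cl)cc4)ncnc32)c2ccccc21` carries a chlorophenyl on its core instead, and in this assay compound 2 gives 8440 nM. Compound 3 `CC1(C)[C@@H](CO)CC[C@@]1(C)Cn1cnc2c(Cl)ncnc21` carries chloro on its core, and in this assay compound 3 gives 42800 nM. No two of these compounds differ in a single place, so no measured step can be drawn between them.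

Compound 4 `O[C@H]1C[C@@H](Cn2cnc3c(-c4ccccc4)ncnc32)c2ccccc21` has not yet been measured. It differs from compound 1 in one place: phenyl in place of hydroxy on an aromatic carbon. The hydroxy leaves, and a phenyl enters on the same aromatic carbon of the core.

Compound 4 is expected to be a clearly stronger inhibitor than compound 1, and the step of an at least 13-fold lower number from compound 1 to compound 4 (1.12 log units; beyond the scatter) is expected to lie well beyond the scatter. This expectation rests on compound 2, which carries a closely related chlorophenyl at the core and gives 8440 nM. In this assay compound 4 is estimated at 15000 nM, with a likely range from 3000 nM to 80000 nM.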

Compound 4, half-maximal inhibitory concentration: > 200000 nM
Compound 4: no number, only a limit; the forecaster's own chance of this, stated with the estimate: 10%; middle value at least 13-fold (1.12 log units) away from the limit.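

Compound 1 and compound 4 both rest at a limit of the assay and not at a measured number, so the step between them cannot be read: the limit of > 200000 nM in this assay, at which 2 of the 4 values shown sit.

The compounds shown leave open how far, if at all, phenyl in place of hydroxy on an aromatic carbon of the shared core moves the number in this assay.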